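Ethyl for Chloro on a Urea Near the Assay Limit

A few compounds are considered here, and "the series" means these few. Any claim that something is new, unique, unknown or untested is made for them only; others in the source may bear on it.

Compound 1 `COc1ccc(CN(C(=O)Nc2ccc(Cl)cc2)n2cnnc2)cc1OC` was examined in a functional assay on MCF7 cells (Homo sapiens) for cytotoxicity, read by MTT assay, with a stated time of 48 h; on this read-out lower numbers stand for stronger inhibition and higher numbers for weaker inhibition. In this assay compound 1 gives only a limit, > 50000 nM. Compound 2 `COc1ccc(CN(C(=O)Nc2ccc(Cl)c(C(F)(F)F)c2)n2cnnc2)cc1OC` likewise gives only a limit in this assay, > 50000 nM. Among the measured compounds shown here, compound 3 `Cc1ccc(NC(=O)N(Cc2ccccn2)n2cnnc2)cc1` is the one compound with a number, 38900 nM in this assay. For the measured compounds named here, the single step between measured compounds that differ in one place, a step that the two limits leave unreadable from compound 1 to compound 2, is therefore not readable, and the limit of > 50000 nM in this assay, at which 2 of the 3 values shown sit, is where two of the three values sit.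

Compound 4 `CCc1ccc(NC(=O)N(Cc2ccc(OC)c(OC)c2)n2cnnc2)cc1` differs from compound 1 by ethyl in place of chloro on an aromatic carbon. Going by the values given here, no measured step exchanges a group at this position, so none bears directly on the change. Because the limit of > 50000 nM in this assay, at which 2 of the 3 values shown sit, holds compound 1 itself, the starting point is a limit and a step from it cannot be read in either direction.

Compound 4 is therefore expected to stay near the limit, with an estimated value of 50000 nM and a range from 20000 nM to 150000 nM. The expected step of a number no higher from compound 1 to compound 4 (the limit leaves the size open) is estimated to be none beyond the scatter.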

Compound 4, half-maximal inhibitory concentration: > 50000 nM
Compound 4: a limit, no number; the forecaster's own chance of this, stated with the estimate: 60%; the middle value lies on the limit itself.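

In this assay compound 4 gives only a limit, > 50000 nM. Among the compounds shown here, compound 1 gives only a limit as well, so no step between compound 1 and compound 4 can be read. The compounds shown leave open how ethyl and chloro compare at this place, with the values resting here: the limit of > 50000 nM in this assay, at which 3 of the 4 values shown sit.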